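The source may report more compounds than this note shows. Statements on the series, on what has been measured and on what is new or still open speak of the compounds shown alone.

In a physicochemical assay for solubility, read by spectrophotometry, in phosphate buffer, with a stated time of 2 h, at pH 7.4 (a higher number here means a more soluble compound, a lower number a less soluble compound), compound 3 `COc1ccc2[nH]c(C(=O)N3CC(=O)N(Cc4ccoc4)[C@@H](Cc4ccccc4)C3)cc2c1` gives 63600 nM, the highest of the two plain numbers shown; the nearest is compound 1 `COc1ccc2[nH]c(C(=O)N3CC(=O)N(Cc4ccccc4)[C@@H](COCc4ccccc4)C3)cc2c1`, which gives 8800 nM. Compound 2 `COc1ccc2[nH]c(C(=O)N3CC(=O)N(Cc4ccccc4)[C@@H](CN4CCC(OC)CC4)C3)cc2c1` is reported only as > 25000 nM, which is a limit of the assay rather than a number. Going by the values given here, the single measured step, an at least 2.8-fold higher number from compound 1 to compound 2 (0.45 log units; beyond the scatter), alters the group on the saturated chain and leaves the amide nitrogen substituent untouched. Compound 4 `COc1ccc2[nH]c(C(=O)N3CC(=O)N(c4ccccc4)[C@@H](Cc4ccccc4)C3)cc2c1` differs from compound 3 by phenyl in place of (furan-3-yl)methyl on an amide-type nitrogen in a ring. Among the compounds with values here, no measured step bears on that position, so the expectation rests on compound 3 alone. A modest downward step is expected, a 2.5-fold lower number from compound 3 to compound 4 (0.41 log units; beyond the scatter). Compound 4 is therefore estimated at 25000 nM, with a range from 8000 nM to 80000 nM.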

Compound 4, solubility: 36100 nM
Beside the measured number, compound 4's estimate is 1.4-fold (0.16 log units) below it, and the stated range covers the measured number.
By their numbers in this assay, from the lowest: compound 1; then compounds 4 and 3 (each within the scatter of the next).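

In this assay, going by these compounds alone, the step at the amide-type nitrogen in a ring, a 1.8-fold lower number from compound 3 to compound 4 (0.25 log units; within the scatter), is the first reading at this position, and it does not separate phenyl from (furan-3-yl)methyl. No measurement at hand gives a cause for this step. The compounds shown leave open how the furan ring and the methyl link each count alone, since phenyl replaces both at once. Also open, as far as these compounds go, is whether an amine or a carboxylic acid on that phenyl, or a longer chain on this nitrogen, would give a step beyond the scatter.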